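Allyloxy to Benzamido at the Edge of Measurement

The compounds below may be only part of what the source reports. "The series", "measured", "known", "first", "only" and "open" are said of these compounds alone.

Of the compounds shown here, two sharing a common core have been tested in an ADME assay on DU-145 cells (Homo sapiens) for cytotoxicity, read by MTT assay, with a stated time of 72 h; a lower number here means a stronger inhibitor, a higher number a weaker inhibitor. Compound 1 `COc1ccc(C2=C(c3cc(OC)c(OC)c(OC)c3)C(=O)C(OC(C)=O)C2)cc1OC(C)C` gives > 100 ug/mL in this assay, a figure that is a limit of the assay rather than a measured number. Compound 2 `C=CCOc1cc(C2=C(c3cc(OC)c(OC)c(OC)c3)C(=O)C(O)C2)ccc1OC` likewise gives > 100 ug/mL in this assay, again a limit and not a number. Among the measured compounds shown here, compound 2 therefore stands at the limit, and the one other value shown sits there too (the limit of > 100 ug/mL in this assay, at which 2 of the 2 values shown sit); no step between the two measured compounds can be read off.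

Compound 3 `COc1ccc(C2=C(c3cc(OC)c(OC)c(OC)c3)C(=O)C(O)C2)cc1NC(=O)c1ccccc1` has not yet been measured. It differs from compound 2 in one place: benzamido in place of allyloxy on an aromatic carbon. With both known values resting at the limit, the step of a number no higher from compound 2 to compound 3 (the limit leaves the size open) is expected to stay within the usual scatter. Compound 3 is thus expected to give about 100 ug/mL in this assay, with a range from 30 ug/mL to 300 ug/mL, most likely reported once more as a limit.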

Compound 3, half-maximal inhibitory concentration: > 100 ug/mL
Compound 3 ended at the assay's limit (the forecaster's own chance of this, stated with the estimate: 70%); the middle value sits exactly at the limit.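

Compound 2 and compound 3 both rest at a limit of the assay rather than at a number, so no step can be read between them: the limit of > 100 ug/mL in this assay, at which 3 of the 3 values shown sit. The compounds shown leave open how strong any of them is in this assay and whether benzamido and allyloxy differ there at all.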